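A few compounds are considered here, and "the series" means these few. Any claim that something is new, unique, unknown or untested is made for them only; others in the source may bear on it.

Working notes on the series, read in a functional assay with Cavia porcellus as the target; a higher number here means that more compound is needed for the effect, a lower number that less compound is needed. Compound 1 (`COC(=O)c1c[nH]c(C)c1C(=O)c1ccccc1Cc1ccccc1`) gives 144 nM. Compound 2 (`COC(=O)c1c(C)[nH]c(C)c1C(=O)c1ccccc1Br`) gives 8950 nM, the higher of the two numbers, and its gap to compound 1 lies beyond the scatter. Compound 3 (`COC(=O)c1c(C)[nH]c(C)c1C(=O)c1ccccc1`) has not yet been measured in this assay. It differs from compound 2 by hydrogen in place of bromo on an aromatic carbon. For the measured compounds named here, no step between measured compounds isolates this change, so the series offers no direct precedent. Both measured compounds keep a group other than hydrogen at this place, with compound 2 at 8950 nM already high, and a moderate rise in the number is expected, though the uncertainty is wide. The expected change is a 2.2-fold higher number from compound 2 to compound 3 (0.35 log units; beyond the scatter). The estimated value for compound 3 is 20000 nM, with an expected range of 4000 nM to 100000 nM.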

Compound 3, half-maximal effective concentration: 21900 nM
Compound 3: middle estimate off by 1.1-fold (0.04 log units), on the low side; the range from low to high includes it.
By their numbers in this assay, from the lowest: compound 1; then compound 2; then compound 3.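

In this assay the series now holds its first step that isolates this position: hydrogen in place of bromo on an aromatic carbon, ortho to a large group, gives a 2.4-fold higher number from compound 2 to compound 3 (0.39 log units; beyond the scatter) and the step counts as modest. The group at this place therefore bears on the number, with more compound needed when hydrogen stands there than when bromo does. Nothing available on these compounds bears on why the number moves with this exchange.

On these data alone, whether another group at this place, such as chloro, methoxy or an amine, would lower the number further or leave it in the same range remains open. Compound 1 carries a benzyl group at this position but differs from compound 2 in more than one place, so the contribution of that group cannot be read on its own.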